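This account rests on a few compounds, and the source may have more. Where it says the series, first, only, none or still open, it means among the compounds named here.

Measured compounds:
compound 1 `Cc1ccc(S/C(=C/c2c[nH]c3ccccc23)C(=O)c2ccc(Br)cc2)cc1`: 10000 nM
compound 2 `Cc1ccc(S/C(=C/c2c[nH]c3ccccc23)C(=O)c2ccc(Cl)cc2)cc1`: 10000 nM
compound 3 `O=C(/C(=C\c1c[nH]c2ccccc12)S(=O)(=O)c1ccc(Br)cc1)c1ccc(Br)cc1`: 25000 nM

In a functional assay on DU-145 cells (Homo sapiens) for inhibition, read by trypan blue exclusion, with a stated time of 96 h (a higher number here means a weaker inhibitor of growth, a lower number a stronger inhibitor of growth), compound 1 gives 10000 nM. Compound 2 gives 10000 nM, and the step of no change at the digits printed from compound 1 to compound 2 (within the scatter) shows that the halogen swap makes no difference that can be trusted. Compound 3 gives 25000 nM, and the step of a 2.5-fold higher number from compound 1 to compound 3 (0.40 log units; beyond the scatter) is a modest weakening. Compound 1 therefore stands level with compound 2 at the lowest number of the three, with compound 3 the furthest away.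

Compound 4 `CC(=O)c1ccc(/C=C(/Sc2ccc(C)cc2)C(=O)c2ccc(Br)cc2)cc1` differs from compound 1 in one place: 4-acetylphenyl in place of 1H-indol-3-yl on a double-bonded chain carbon bound to a double-bonded chain carbon. Neither measured step touches this part of the molecule. One exchanges a halogen on an aromatic carbon; the other exchanges the sulfur-bearing group on the chain carbon bound to the carbonyl carbon. Both left the number within a small range, and neither tells how the growth inhibition responds when the aromatic group on the other chain carbon is changed. The expectation for compound 4 can rest only on the level at which compound 1 sits, 10000 nM, and must carry a wide range.

Compound 4 is thus estimated at 12000 nM, with a range from 4000 nM to 40000 nM. The expected step of a 1.2-fold higher number from compound 1 to compound 4 (0.08 log units; within the scatter) is judged likely to stay within the scatter, in no clear direction.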

Compound 4, concentration for 50% growth inhibition: 50000 nM
Estimate against measurement, compound 4: 4.2-fold (0.62 log units) below; measured number outside the range, above it.
By their numbers in this assay, from the lowest: compounds 1 and 2 (each within the scatter of the next); then compounds 3 and 4 (each within the scatter of the next).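

In this assay, 4-acetylphenyl in place of 1H-indol-3-yl gives a 5.0-fold higher number from compound 1 to compound 4 (0.70 log units; beyond the scatter), so growth inhibition does respond to the aromatic group at this place on the double-bonded chain carbon, something the halogen and sulfonyl steps could not show. The two groups have the same heavy-atom count, yet the exchange changes several things at once: 1H-indol-3-yl brings a five-membered aromatic ring and a hydrogen-bond donor, while 4-acetylphenyl brings a hydrogen-bond acceptor and a double bond outside the ring. Nothing available here says which of these differences matters, or why the number moves.

On these data alone, it remains open whether the step follows from losing the indole ring or from adding the acetyl group, a question that plain phenyl and 4-hydroxyphenyl at the same place could help separate. As far as these compounds go, it is also open whether the same exchange would give a similar step on the chloro compound 2 or the sulfonyl compound 3, whose other groups differ from those of compound 1.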